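A methyl group on the hydroxyethyl amide chain

The source may hold more compounds than are shown below. What is called first, only, known or untested is meant among the compounds shown, and "the series" means these compounds.

Measured in a functional assay on MCF7 cells (Homo sapiens) for antiproliferative activity, read by MTT assay, with a stated time of 24 h; on this read-out higher numbers stand for weaker inhibition and lower numbers for stronger inhibition:
Compound 1 `CCn1c(C(=O)NCCNC(=O)OC(C)(C)C)ccc1C(CC)(CC)c1ccc(OCS(=O)(=O)c2ccccc2)c(C)c1`: > 50000 nM
Compound 2 `CCn1c(C(=O)NCCN)ccc1C(CC)(CC)c1ccc(OCS(=O)(=O)c2ccccc2)c(C)c1`: 6470 nM
Compound 3 `CCn1c(C(=O)NCCO)ccc1C(CC)(CC)c1ccc(OCS(=O)(=O)c2ccccc2)c(C)c1`: 15500 nM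

In this assay compound 1 stands at a limit, > 50000 nM, and not at a number. Of the two actual numbers, compound 3 holds the higher one, 15500 nM, and the nearest is that of compound 2.

Compound 4 `CCn1c(C(=O)N[C@H](C)CO)ccc1C(CC)(CC)c1ccc(OCS(=O)(=O)c2ccccc2)c(C)c1` turns the 2-hydroxyethyl group of compound 3 into 1-(hydroxymethyl)ethyl: methyl in place of hydrogen on a saturated chain carbon bound to an amide-type nitrogen and a saturated chain carbon.

The measured steps bear on this only indirectly, since all of them change the end of the chain and none adds a methyl on this carbon. The closest guide is the modest 2.4-fold higher number from compound 2 to compound 3 (0.38 log units; beyond the scatter). The two steps out of the limit, an at least 7.7-fold lower number from compound 1 to compound 2 (0.88 log units; beyond the scatter) and an at least 3.2-fold lower number from compound 1 to compound 3 (0.50 log units; beyond the scatter), are larger, but each removes a whole tert-butoxycarbonyl-bearing end.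

A small change in this assay is therefore expected, with no clear direction and quite possibly nothing beyond the scatter. The expected result is a 1.0-fold lower number from compound 3 to compound 4 (0.01 log units; within the scatter). For compound 4 the estimate is 15000 nM, with an expected range from 6000 nM to 40000 nM.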

Compound 4, half-maximal inhibitory concentration: 10600 nM
The estimate for compound 4 lay 1.4-fold (0.15 log units) above the measured number; low and high end bracket the measured number.
By their numbers in this assay, from the lowest: compounds 2, 4 and 3 (each within the scatter of the next, the first and the last beyond it). At a limit, above all of these: compound 1.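

In this assay the methyl on this saturated chain carbon, bound to an amide-type nitrogen and a saturated chain carbon, gives a 1.5-fold lower number from compound 3 to compound 4 (0.17 log units; within the scatter) and is the first change shown at this place, one the chain takes up with no shift that can be told from the scatter. Compounds 2 and 3 stood apart beyond the scatter, yet a 1.6-fold higher number from compound 2 to compound 4 (0.21 log units; within the scatter) leaves the 1-(hydroxymethyl)ethyl amide inseparable from the 2-aminoethyl amide. Among these compounds, compound 1 stands at a limit and not at a number, so an at least 4.7-fold lower number from compound 1 to compound 4 (0.67 log units; beyond the scatter) shows only that compound 4 lies clear of that limit.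

Nothing among the data shown speaks to a reason for this result. Open among the compounds shown are the mirror-image 1-(hydroxymethyl)ethyl group, an ethyl in place of this methyl, and a carboxylic acid at the chain end.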